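Aryl group on the aromatic nitrogen: the step to compound 4

A few compounds are considered here, and "the series" means these few. Any claim that something is new, unique, unknown or untested is made for them only; others in the source may bear on it.

Among the compounds with values here, compound 3 `CC(C(=O)NCc1cc(C(F)(F)F)nn1-c1ccc(OC(F)(F)F)cc1)c1ccc2c(c1)CCC2` gives 51.6 nM in an assay on CHO-K1 cells for antagonist activity at transient receptor potential cation channel subfamily V member 1 (Homo sapiens), read by FLIPR (on this read-out higher numbers stand for weaker inhibition and lower numbers for stronger inhibition), the highest of the three numbers known so far. Compound 2 `CC(C(=O)NCc1cc(C(F)(F)F)nn1-c1ccc(C(F)(F)F)cc1)c1ccc2c(c1)CCC2` gives 51.3 nM, and the two lie within the scatter, a 1.0-fold higher number from compound 2 to compound 3 (0.00 log units; within the scatter), while compound 1 `CC(C(=O)NCc1cc(C(F)(F)F)nn1-c1cccc(C(F)(F)F)c1)c1ccc2c(c1)CCC2` gives 7.5 nM, a 6.9-fold higher number from compound 1 to compound 3 (0.84 log units; beyond the scatter). The steps of a 6.8-fold higher number from compound 1 to compound 2 (0.84 log units; beyond the scatter) and a 6.9-fold higher number from compound 1 to compound 3 (0.84 log units; beyond the scatter) are the only ones that bear on the aryl group. Compound 4 `CC(C(=O)NCc1cc(C(F)(F)F)nn1-c1ccc(F)c(Cl)c1)c1ccc2c(c1)CCC2` carries 3-chloro-4-fluorophenyl in place of 4-(trifluoromethoxy)phenyl on an aromatic nitrogen. The entering 3-chloro-4-fluorophenyl shares its substitution partly with the 3-(trifluoromethyl)phenyl of compound 1 and partly with the 4-(trifluoromethyl)phenyl of compound 2, so a partial return toward compound 1 is expected, a 3.4-fold lower number from compound 3 to compound 4 (0.54 log units; beyond the scatter), smaller than the full step. Compound 4 is estimated at 15 nM, range 5 nM to 50 nM.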

Compound 4, inhibition constant: 14.7 nM
Compound 4: the middle estimate sits 1.0-fold (0.01 log units) above what was measured, within the range that was stated.
By their numbers in this assay, from the lowest: compounds 1 and 4 (each within the scatter of the next); then compounds 2 and 3 (each within the scatter of the next).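

In this assay, 3-chloro-4-fluorophenyl on the aromatic nitrogen regains most of the ground lost with the other two aryl groups: a 3.5-fold lower number from compound 3 to compound 4 (0.55 log units; beyond the scatter) and a 3.5-fold lower number from compound 2 to compound 4 (0.54 log units; beyond the scatter). Against 3-(trifluoromethyl)phenyl, a 2.0-fold higher number from compound 1 to compound 4 (0.29 log units; within the scatter), so these two aryl groups cannot be told apart at this position. No measurement at hand accounts for these steps.

Open, on these data alone, is whether chlorine or fluorine alone would give the same number. Also open, as far as these compounds go, is how a phenyl bearing an amine or a carboxylic acid would behave here.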